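The source may report more compounds than this note shows. Statements on the series, on what has been measured and on what is new or still open speak of the compounds shown alone.

Measured so far in a functional assay on K562 cells (Homo sapiens) for antiproliferative activity, with a stated time of 72 h; a lower number here means a stronger inhibitor, a higher number a weaker inhibitor:
- Compound 1 `OC[C@H]1O[C@@H](n2cnc3c(NCc4ccc(Cl)cc4Cl)ncnc32)[C@H](O)[C@@H]1O`: 106000 nM
- Compound 2 `OC[C@H]1O[C@@H](n2cnc3c(NCc4ccc(F)c(F)c4F)ncnc32)[C@H](O)[C@@H]1O`: > 166000 nM (a limit, not a number)

Compound 2 has no exact value, only a limit: the limit of > 166000 nM in this assay, at which 1 of the 2 values shown sits. On these data alone, its true potency therefore remains unknown.

The next compound, compound 3 `OC[C@H]1O[C@@H](n2cnc3c(NCc4cc(O)cc(O)c4)ncnc32)[C@H](O)[C@@H]1O`, keeps the shared core and changes one group. It has 3,5-dihydroxyphenyl in place of 2,3,4-trifluorophenyl on a saturated chain carbon bound to a nitrogen on an aromatic ring.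

Among the compounds with values here, only one measured step bears on this, as it changes the group at the same place: an at least 1.5-fold higher number from compound 1 to compound 2 (0.19 log units; that floor lies within the scatter). This step swaps a different pair of groups, and its size is known only as a floor, so it is a loose guide. It offers no firm reason to expect a step beyond the scatter in this assay, in either direction.

Within the data shown here, the only exact number is for compound 1, at 106000 nM, so the expectation stays in that high range. Compound 3 is expected at 140000 nM, with an estimated range of 50000 nM to 400000 nM. This estimate means an expected at least 1.1-fold lower number from compound 2 to compound 3 (0.07 log units; that floor lies within the scatter).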

Compound 3, half-maximal inhibitory concentration: > 166000 nM
Compound 3 was reported as a limit; the forecaster's own chance of this, stated with the estimate: 55%; at least 1.1-fold (0.07 log units) between middle value and limit.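

Compound 3 gives > 166000 nM in this assay, which is a limit and not a number. Within the data shown here, with 3,5-dihydroxyphenyl, which counts 2 hydrogen-bond donors and 2 hydrogen-bond acceptors where 2,3,4-trifluorophenyl counts none, this place has now held two quite different rings without an exact value appearing, and the one step that can be read is an at least 1.5-fold higher number from compound 1 to compound 3 (0.19 log units; that floor lies within the scatter). That step gives no firm sign of a change from the dichlorinated compound, and the step from compound 2 to compound 3 cannot be read because both compounds sit at the same limit: the limit of > 166000 nM in this assay, at which 2 of the 3 values shown sit.

On these data alone, the true potencies of compound 2 and compound 3 remain unknown, so it is still open whether the fluorine and hydroxyl versions differ at all in this assay. As far as these compounds go, it is also open whether an amine or a carboxylic acid on the phenyl ring, or a longer chain at this place, would bring a clearly lower number than the high values seen so far.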